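Working notes: the step from compound 3 to compound 4

The source may report more compounds than this note shows. Statements on the series, on what has been measured and on what is new or still open speak of the compounds shown alone.

In a functional assay on BT-483 cells (Homo sapiens) for cytotoxicity, read by MTT assay, with a stated time of 24 h (a lower number here means a stronger inhibitor, a higher number a weaker inhibitor), compound 3 `CCNc1cc(-c2ccc(NC(=O)Nc3cccc4ccccc34)cc2C)ccn1` gives > 30000 nM. That entry is a limit of the assay and not a number.

Two close relatives carry the same core and differ only in the group on the amide-type nitrogen. Compound 1 `CCNc1cc(-c2ccc(NC(=O)Nc3cccc(Cl)c3)cc2C)ccn1` gives 16600 nM, and compound 2 `CCNc1cc(-c2ccc(NC(=O)Nc3ccc(OC)cc3)cc2C)ccn1` gives 25800 nM.

The next structure, compound 4 `CCNc1cc(-c2ccc(NC(=O)Nc3c(C)cccc3C)cc2C)ccn1`, has 2,6-dimethylphenyl in place of naphthalen-1-yl on an amide-type nitrogen.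

Three measured steps change this same place: a 1.6-fold higher number from compound 1 to compound 2 (0.19 log units; within the scatter), an at least 1.8-fold higher number from compound 1 to compound 3 (0.25 log units; that floor lies within the scatter) and an at least 1.1-fold higher number from compound 2 to compound 3 (0.06 log units; that floor lies within the scatter). None of them goes beyond the scatter, although the last two are only floors. For the measured compounds named here, no measured compound carries 2,6-dimethylphenyl, so these steps give only a general guide to the size of a change here.

On that basis no step beyond the scatter is expected in this assay, in either direction. The expected step is an at least 1.2-fold lower number from compound 3 to compound 4 (0.09 log units; that floor lies within the scatter), and this estimate is loose, as its starting point is only a limit. A further limit reading would also fit this expectation.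

The estimated value for compound 4 is 24000 nM, with an expected range of 12000 nM to 48000 nM.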

Compound 4, half-maximal inhibitory concentration: > 30000 nM
Compound 4 gave a limit, no number; the forecaster's own chance of this, stated with the estimate: 45%; middle value at least 1.2-fold (0.09 log units) from the limit.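

In this assay, for the compounds shown here, compound 4 gives > 30000 nM, which is a limit of the assay and not a number, so the change from naphthalen-1-yl to 2,6-dimethylphenyl cannot be read, and no step between the two limit compounds can be given a size. Against the two relatives with numerical values, the readings are an at least 1.1-fold higher number from compound 2 to compound 4 (0.06 log units; that floor lies within the scatter) and an at least 1.8-fold higher number from compound 1 to compound 4 (0.25 log units; that floor lies within the scatter); as floors, neither establishes a separation from compound 1 or compound 2. New here is that the limit reading on the amide-type nitrogen is not confined to naphthalen-1-yl, with its two six-membered aromatic rings, since 2,6-dimethylphenyl, with one such ring, shares it: the limit of > 30000 nM in this assay, at which 2 of the 4 values shown sit.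

From the compounds shown here alone, how far compound 3 and compound 4 lie past this limit remains unknown, so no order can be set among compound 1, compound 2, compound 3 and compound 4 in this assay. Also open, going by these compounds, is whether a phenyl group carrying a carboxylic acid or an amine, or a longer alkyl chain, on this nitrogen would give a value clearly apart from that of compound 1.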